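A few compounds are considered here, and "the series" means these few. Any claim that something is new, unique, unknown or untested is made for them only; others in the source may bear on it.

Compound 1 `COc1ccccc1C#Cc1csc(C)n1`: 36.3 nM
Compound 2 `Cc1nc(C#Cc2cccc(Cl)c2)cs1`: 129 nM

For the measured compounds named here, in a functional assay on CHO cells for agonist activity at metabotropic glutamate receptor 5 (Homo sapiens), read by inositol phosphate accumulation (on this read-out higher numbers stand for weaker inhibition and lower numbers for stronger inhibition), compound 2 gives the higher of the two numbers measured so far, 129 nM. Compound 1, with a different group on its phenyl ring, gives 36.3 nM, and the gap between the two lies beyond the usual scatter, so compound 2 is the weaker of the pair on this read-out.

Going by the values given here, the next compound, compound 3 `Cc1nc(C#Cc2cccc(O)c2)cs1`, keeps the shared core of compound 2 and changes only one group: hydroxy in place of chloro on an aromatic carbon. Among the compounds with values here, no pair of measured compounds that differ in this way is available, so the size and direction of the step can only be guessed. The expectation is a moderate step toward a higher number, that is toward weaker inhibition, with a 3.1-fold higher number from compound 2 to compound 3 (0.49 log units; beyond the scatter) as the estimated step from compound 2 to compound 3. In this assay compound 3 is therefore expected to give about 400 nM, within a range of 100 nM to 2000 nM.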

Compound 3, half-maximal inhibitory concentration: 654 nM
Compound 3: middle estimate off by 1.6-fold (0.21 log units), on the low side, within the range that was stated.
By their numbers in this assay, from the lowest: compound 1; then compound 2; then compound 3.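

In this assay, putting hydroxy in place of chloro on an aromatic carbon, meta to a group of 8 heavy atoms, gives a 5.1-fold higher number from compound 2 to compound 3 (0.70 log units; beyond the scatter), a move toward weaker inhibition. So exchanging a single heavy atom at this place is enough to shift the number beyond the usual scatter. The two groups have the same heavy-atom count, while hydroxy brings one hydrogen-bond donor and one hydrogen-bond acceptor where chloro brings none, but a single pair cannot show which of these differences matters, and no measured property of these compounds is available to explain the step.

The compounds shown leave open how other groups at this place would compare, such as an amine, a carboxylic acid or a fluoro group, and so whether chloro and hydroxy are typical of what this carbon tolerates. They also leave open whether the same exchange, made on a different carbon of the ring, would give a step of similar size and direction.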